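The source may report more compounds than this note shows. Statements on the series, on what has been measured and on what is new or still open speak of the compounds shown alone.

Compound 1 `C[C@H]1CN(c2cccc3ccccc23)CCN1CN1CC(=O)N2CCC[C@H]2C1=O` — in an assay on membranes from Cerebral cortex for binding affinity to Adrenergic receptor alpha-1 (Rattus norvegicus) (a lower number here means a stronger inhibitor, a higher number a weaker inhibitor), compound 1 gives > 1000 nM, which is a limit of the assay and not a number.
Compound 2 `C[C@@H]1CN(c2cccc3ccccc23)CCN1CN1CC(=O)N2CCC[C@@H]2C1=O` — in this assay compound 2 gives > 1000 nM, again a limit of the assay and not a number.

Compound 2 therefore stands at the limit, where both values shown sit (the limit of > 1000 nM in this assay, at which 2 of the 2 values shown sit). Going by the values given here, the only measured step, a step that the two limits leave unreadable from compound 1 to compound 2, is left unreadable by the two limits, even though compounds 1 and 2 are mirror images (the fact that compounds 1 and 2 differ only in the configuration as drawn). Compound 3 `C[C@H]1CN(c2cccc3ccccc23)CCN1CN1CC(=O)N2CCC[C@@H]2C1=O` differs from compound 2 in configuration only: the two compounds have the same atoms and bonds and differ only in configuration as drawn: 1 of 2 stereo elements differ; a stereocentre at a saturated ring carbon is drawn R in compound 2 and S in compound 3. Among the compounds with values here, compound 3 is thus the diastereomer of both measured compounds, and no measured step can give a direction or size for this change, so no step beyond the scatter can be predicted in either direction. Compound 3 is expected to remain at or near the limit, estimated at 2000 nM with a range from 400 nM to 10000 nM, and the step from compound 2 is expected to be a step that the limit leaves unreadable from compound 2 to compound 3.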

Compound 3, inhibition constant: > 1000 nM
Compound 3 was reported as a limit; the forecaster's own chance of this, stated with the estimate: 70%; the middle value lies beyond the limit too.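

No new step can be read among compound 1, compound 2 and compound 3 in this assay, where all three sit at a limit of the assay and not at a number: the limit of > 1000 nM in this assay, at which 3 of the 3 values shown sit.

The compounds shown leave open whether configuration at either stereocentre changes the true values that lie beyond this limit.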